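The compounds below may be only part of what the source reports. "The series", "measured", "known", "first", "only" and "open" are said of these compounds alone.

Measured in a functional assay on KB cells (Homo sapiens) for antiproliferative activity, read by MTT assay, with a stated time of 48 h; a lower number here means a stronger inhibitor, a higher number a weaker inhibitor:
Compound 1 `Cn1cc(C2=C(c3nn(CCCN4CCCCC4)c4ncccc34)C(=O)N(c3cccc4ccccc34)C2=O)c2ccccc21`: 13400 nM
Compound 2 `Cn1cc(C2=C(c3nn(CCCN4CCCCC4)c4ncccc34)C(=O)NC2=O)c2ccccc21`: 98000 nM

Of these two compounds, compound 2 stands at the higher number, 98000 nM, and is therefore the weaker inhibitor in this assay. Compound 3 `COc1ccc(N2C(=O)C(c3cn(C)c4ccccc34)=C(c3nn(CCCN4CCCCC4)c4ncccc34)C2=O)cc1` departs from compound 2 at a single place, with 4-methoxyphenyl in place of hydrogen on an amide-type nitrogen in a ring.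

For the measured compounds named here, only one measured step bears on this change: a 7.3-fold higher number from compound 1 to compound 2 (0.86 log units; beyond the scatter). That step is modest but beyond the scatter, and it comes from hydrogen in place of naphthalen-1-yl on an amide-type nitrogen in a ring. On this single step, a change of similar size in the opposite direction, toward a lower number in this assay, is expected for compound 3, with compound 1 at 13400 nM as the guide. Going by the values given here, the data hold no measured 4-methoxyphenyl example, so this expectation remains uncertain. The estimated step is a 5.8-fold lower number from compound 2 to compound 3 (0.76 log units; beyond the scatter). For compound 3 the expected value is 17000 nM, with an estimated range from 5000 nM to 60000 nM.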

Compound 3, half-maximal inhibitory concentration: 44000 nM
Compound 3: middle estimate off by 2.6-fold (0.41 log units), on the low side; the range from low to high includes it.
By their numbers in this assay, from the lowest: compound 1; then compound 3; then compound 2.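

In this assay, 4-methoxyphenyl on the amide-type nitrogen in a ring also gives a lower number than hydrogen (a 2.2-fold lower number from compound 2 to compound 3 (0.35 log units; beyond the scatter)), so this direction of change is no longer tied to naphthalen-1-yl alone. The size of the effect does depend on the group, however: the exchange of naphthalen-1-yl for 4-methoxyphenyl gives a higher number (a 3.3-fold higher number from compound 1 to compound 3 (0.52 log units; beyond the scatter)), which places the 4-methoxyphenyl compound between the other two and shows that this position responds to which ring-bearing group is attached, not just to the loss of hydrogen. Nothing available on these compounds accounts for this order among hydrogen, 4-methoxyphenyl and naphthalen-1-yl.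

The compounds shown leave open what the methoxy group itself contributes, since a plain phenyl group on this nitrogen would be needed to separate it from the aromatic ring that carries it. They also leave open whether a group without an aromatic ring, such as methyl or a longer alkyl chain, would lower the number from that of the compound with hydrogen at this position.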